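This account rests on a few compounds, and the source may have more. Where it says the series, first, only, none or still open, it means among the compounds named here.

Measured so far:
Compound 1 `CN1C[C@@H](COc2ccc(C(=O)n3ccc4c(CC(=O)O)cccc43)cc2)Oc2ccccc21` — 2500 nM
Compound 2 `Cc1cc(OC[C@@H]2CN(C)c3ccccc3O2)cc(C)c1C(=O)Nc1cccc(CC(=O)O)c1` — > 10000 nM

Of the compounds shown here, two have been measured in an assay on CHO cells for displacement of a labelled ligand from prostacyclin receptor (Homo sapiens), read by scintillation counting, with a stated time of 30 min; a higher number here means a weaker inhibitor, a lower number a stronger inhibitor. Compound 1 `CN1C[C@@H](COc2ccc(C(=O)n3ccc4c(CC(=O)O)cccc43)cc2)Oc2ccccc21` gives 2500 nM. Compound 2 `Cc1cc(OC[C@@H]2CN(C)c3ccccc3O2)cc(C)c1C(=O)Nc1cccc(CC(=O)O)c1` returns only a limit of the assay, > 10000 nM, so its true inhibition constant is not known, only that it lies beyond the range the assay reports. Compound 2 therefore sits at the limit of > 10000 nM in this assay, at which 1 of the 2 values shown sits, and nothing can be said about how far past that limit it lies.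

Compound 3 `Cc1ccc(CC(=O)O)cc1NC(=O)c1c(C)cc(OC[C@@H]2CN(C)c3ccccc3O2)cc1C` has not yet been measured. It differs from compound 2 in one place: methyl in place of hydrogen on an aromatic carbon. In words, a methyl takes the place of a hydrogen on an aromatic carbon of a six-membered aromatic ring of carbon only, and the change reads 3-(carboxymethyl)phenyl to 5-(carboxymethyl)-2-methylphenyl.

Going by the values given here, no measured step between two compounds exists to show what such a change does in this assay. Since compound 2 starts at a limit, the step from compound 2 to compound 3 is expected to be small or within the scatter, as an at least 1.1-fold lower number from compound 2 to compound 3 (0.04 log units; that floor lies within the scatter) indicates. Compound 3 is expected to give about 9000 nM, within a range from 2500 nM to 30000 nM, with a fair chance that the assay again reports only a limit.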

Compound 3, inhibition constant: > 10000 nM
Compound 3: only a limit was reported; the forecaster's own chance of this, stated with the estimate: 55%; middle value at least 1.1-fold (0.04 log units) away from the limit.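

No step can be read between compound 2 and compound 3, because each returns only a limit of the assay and not a number: the limit of > 10000 nM in this assay, at which 2 of the 3 values shown sit.

The compounds shown leave open whether a methyl in place of this hydrogen makes any difference in this assay, and how far past the limit either compound lies.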